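The source may report more compounds than this note shows. Statements on the series, on what has been measured and on what is new or still open speak of the compounds shown alone.

Measured so far in a physicochemical assay for lipophilicity, using the shake flask method; a lower number here means a more polar compound, a higher number a more lipophilic compound:
- compound 1 `Cc1ccc(NC(=O)c2cc(Oc3ccc(S(C)(=O)=O)cc3)cc(OC(C)C)c2)nc1`: 4.05
- compound 2 `CC(C)Oc1cc(Oc2ccc(S(C)(=O)=O)cc2)cc(-c2cccc(=O)[nH]2)c1`: 2.82
- compound 3 `CC(C)Oc1cc(Oc2ccc(S(C)(=O)=O)cc2)cc(-c2ccnc(=O)[nH]2)c1`: "not determined" (no result reported)

On this read-out, compound 3 has no number to start from, its entry being "not determined" (no result reported). Compound 4 `CC(C)Oc1cc(Oc2ccc(S(C)(=O)=O)cc2)cc(-c2cncc(=O)[nH]2)c1` differs from compound 3 in one place: a group of 7 heavy atoms (4 carbon, 2 nitrogen, 1 oxygen; one six-membered aromatic ring with 2 hetero atoms) in place of a group of 7 heavy atoms (4 carbon, 2 nitrogen, 1 oxygen; one six-membered aromatic ring with 2 hetero atoms), on an aromatic carbon. The two have the same atoms, joined differently, and the group sits on an aromatic carbon, meta to a large group and meta to an isopropoxy group.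

Among the compounds with values here, only one measured step is available, a number 1.23 log units lower from compound 1 to compound 2 (beyond the scatter). That was a large step, but it exchanged a different group, so it bears on this change only indirectly. With the same atoms on both sides, no step beyond the scatter is expected in this assay, and no direction can be given, although the missing value means this cannot be checked.

The nearest measured anchor is compound 2 at 2.82, and the estimate is placed somewhat lower, with a wide range. For compound 4 the expected value is 2.5, estimated to lie between 2 and 3.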

Compound 4, distribution coefficient: 2.27
The estimate for compound 4 lay 0.23 log units above the measured number; the range from low to high includes it.
By their numbers in this assay, from the lowest: compound 4; then compound 2; then compound 1.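

Compound 4 shows that this position still responds in this assay when the group keeps the same count of heavy atoms: a ring with 2 hetero atoms in place of a ring with 1 hetero atom gives a number 0.55 log units lower from compound 2 to compound 4 (beyond the scatter), a modest but real change. Set against the larger exchange, which gives a number 1.78 log units lower from compound 1 to compound 4 (beyond the scatter), this adds to the drop already seen for compound 2. Nothing measured here explains why the number moves.

From the compounds shown here alone, compound 3 has the same atoms as compound 4, joined differently, but it has no number in this assay, so the step between them cannot be read and the effect of where the ring atoms sit stays unknown. Going by these compounds, how an amine or a carboxylic acid at this position would compare also remains open.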